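A few compounds are considered here, and "the series" means these few. Any claim that something is new, unique, unknown or untested is made for them only; others in the source may bear on it.

Among the compounds with values here, compound 3 `CCn1c(C(=O)N[C@@H](CC(=O)OC)C(=O)OC)ccc1C(CC)(CC)c1ccc(OCS(=O)(=O)c2ccccc2)c(C)c1` carries the only number in this set: in a functional assay on PC-3 cells (Homo sapiens) for antiproliferative activity, read by MTT assay, with a stated time of 24 h (a higher number here means a weaker inhibitor, a lower number a stronger inhibitor), compound 3 gives 6490 nM. Compound 1 `CCn1c(C(=O)NCC(=O)OC)ccc1C(CC)(CC)c1ccc(OCS(=O)(=O)c2ccccc2)c(C)c1` reaches only a limit of the assay, > 50000 nM. Compound 2 `CCn1c(C(=O)N[C@H](C)C(=O)OC)ccc1C(CC)(CC)c1ccc(OCS(=O)(=O)c2ccccc2)c(C)c1` likewise stops at a limit, > 50000 nM. Compound 4 `CCN(CC)CCNC(=O)c1ccc(C(CC)(CC)c2ccc(OCS(=O)(=O)c3ccccc3)c(C)c2)n1CC` differs from compound 3 in one place: 2-(diethylamino)ethyl in place of 1,2-bis(methoxycarbonyl)ethyl on an amide-type nitrogen. Within the data shown here, two measured steps bear on this amide side chain, an at least 7.7-fold lower number from compound 1 to compound 3 (0.88 log units; beyond the scatter) and an at least 7.7-fold lower number from compound 2 to compound 3 (0.88 log units; beyond the scatter), both showing that the 1,2-bis(methoxycarbonyl)ethyl chain is what lifts compound 3 off (the limit of > 50000 nM in this assay, at which 2 of the 3 values shown sit). Among the measured compounds shown here, since compound 4 loses that chain entirely, and the 2-(diethylamino)ethyl group has no precedent here, a step of a 2.3-fold higher number from compound 3 to compound 4 (0.36 log units; beyond the scatter) is expected, back toward the limit. Compound 4 is therefore estimated at 15000 nM, within 4000 nM to 50000 nM.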

Compound 4, half-maximal inhibitory concentration: 7130 nM
Estimate against measurement, compound 4: 2.1-fold (0.32 log units) above; the range from low to high includes it.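

In this assay, the amide side chain gives a 1.1-fold higher number from compound 3 to compound 4 (0.04 log units; within the scatter), so 2-(diethylamino)ethyl and 1,2-bis(methoxycarbonyl)ethyl cannot be told apart at this position. Leaving the limit therefore does not require the 1,2-bis(methoxycarbonyl)ethyl chain, as an at least 7.0-fold lower number from compound 2 to compound 4 (0.84 log units; beyond the scatter) and an at least 7.0-fold lower number from compound 1 to compound 4 (0.84 log units; beyond the scatter) show. Compound 1 and compound 2 remain at the limit: the limit of > 50000 nM in this assay, at which 2 of the 4 values shown sit.

From the compounds shown here alone, what remains open is how a carboxylic acid in place of the methyl esters would read. Also open, going by these compounds, is whether a longer chain carrying the diethylamino group would differ from compound 4.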